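Removing a Hydroxy Group: Expected Shift in Lipophilicity

The compounds below may be only part of what the source reports. "The series", "measured", "known", "first", "only" and "open" are said of these compounds alone.

Compound 1, `Oc1ccc(/C=C/c2ccc3c(Cl)cc(Cl)c(O)c3n2)c(O)c1`: 4.68
Compound 2, `Oc1cc(O)cc(/C=C/c2ccc3c(Cl)cc(Cl)c(O)c3n2)c1`: 4.68
Compound 3, `CCOc1ccccc1/C=C/c1ccc2cccc(O)c2n1`: 4.55

These three compounds were read in a physicochemical assay for lipophilicity, read by HPLC; on this read-out lower numbers stand for lower lipophilicity and higher numbers for higher lipophilicity. Compound 1 and compound 2 give the same number at the digits shown, and compound 3 lies a little lower, still within the usual scatter, so none of the three stands apart from the others.

Compound 4, `Oc1ccc(/C=C/c2ccc3c(Cl)cc(Cl)c(O)c3n2)cc1`, has not yet been measured. It differs from compound 1 in one place: hydrogen in place of hydroxy on an aromatic carbon. Within the data shown here, no measured pair shows this exact change, so the size of the step cannot be read from the numbers so far. A hydroxy leaves and hydrogen enters; the expected change is a number 0.42 log units higher from compound 1 to compound 4 (beyond the scatter), a rise beyond the scatter. Compound 4 is expected to give 5.1, within a range from 4.6 to 5.6.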

Compound 4, partition coefficient: 5.07
Compound 4: the middle estimate sits 0.03 log units above what was measured; the measured number falls inside the stated range.
By their numbers in this assay, from the lowest: compounds 3, 1 and 2 (each within the scatter of the next); then compound 4.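

In this assay, this position, an aromatic carbon ortho to a large group, responds to the change: hydrogen in place of hydroxy gives a number 0.39 log units higher from compound 1 to compound 4 (beyond the scatter). This is the first measured step among these compounds, so the size of this swap now rests on a real number, though from a single pair. No measurement at hand explains the shift. Going by these compounds, whether an amine, a methoxy group or fluorine at this position would move the number in the same way remains open. So does the effect of the same swap at the hydroxy group meta to this position.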